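The source may report more compounds than this note shows. Statements on the series, on what has been measured and on what is new or still open speak of the compounds shown alone.

Measured so far in an ADME assay on HepG2 2.2.15 cells (Homo sapiens) for cytotoxicity, read by MTT assay, with stated times of 48 h and 9 days; a lower number here means that less compound is tolerated, a higher number that more compound is tolerated:
- compound 1 `COc1ccc2c(=O)c(/C=C/C(=O)NCc3ccccc3)coc2c1`: 376000 nM
- compound 2 `COc1ccc2c(=O)c(/C=C/C(=O)Nc3ccccc3)coc2c1`: 523000 nM
- compound 3 `COc1ccc2c(=O)c(/C=C/C(=O)NCc3ccc(F)cc3)coc2c1`: 133000 nM

Compound 3 gives the lowest number of the three in this assay; its nearest neighbour is compound 1, the furthest compound 2, and both gaps are beyond the scatter.

The next compound is compound 4 `COc1ccc2c(=O)c(/C=C/C(=O)Nc3ccc(Cl)cc3)coc2c1`. It differs from compound 3 by 4-chlorophenyl in place of 4-fluorobenzyl on an amide-type nitrogen.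

Two of the measured steps bear on this. The exchange of a benzyl-type for a phenyl-type group is covered by a 1.4-fold higher number from compound 1 to compound 2 (0.14 log units; within the scatter), which stayed within the scatter, and by a 3.9-fold lower number from compound 2 to compound 3 (0.59 log units; beyond the scatter), which also carries the fluorine. The effect of adding a halogen to the aromatic ring is seen in a 2.8-fold lower number from compound 1 to compound 3 (0.45 log units; beyond the scatter). Going by the values given here, a chlorine on the ring has no precedent in the measured set, so its contribution cannot be read from any step here. Returning to a phenyl-type group is expected to move the number upward, towards compound 2, while the halogen is expected to hold it part of the way back; the estimated step is a 1.7-fold higher number from compound 3 to compound 4 (0.22 log units; within the scatter), with wide uncertainty.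

For compound 4 in this assay the expected value is 220000 nM, with a range from 80000 nM to 550000 nM.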

Compound 4, half-maximal cytotoxic concentration: 272000 nM
The estimate for compound 4 lay 1.2-fold (0.09 log units) below the measured number; the measured number falls inside the stated range.
By their numbers in this assay, from the lowest: compound 3; then compounds 4, 1 and 2 (each within the scatter of the next).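

In this assay, chloro in place of hydrogen on the phenyl group gives a 1.9-fold lower number from compound 2 to compound 4 (0.28 log units; within the scatter), so this change stays within the scatter, whereas fluoro on the benzyl group gave a 2.8-fold lower number from compound 1 to compound 3 (0.45 log units; beyond the scatter), beyond it. Going by these compounds alone, the comparison with the unsubstituted benzyl amide, a 1.4-fold lower number from compound 1 to compound 4 (0.14 log units; within the scatter), also stays within the scatter, while the exchange for 4-fluorobenzyl, a 2.0-fold higher number from compound 3 to compound 4 (0.31 log units; beyond the scatter), lies beyond it, leaving compound 3 as the only compound with steps to all three others printed beyond the scatter. No measurement is available that accounts for these differences.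

As far as these compounds go, whether the separation of compound 3 belongs to the fluorine alone or to fluorine combined with the benzyl group remains open; 4-fluorophenyl and 4-chlorobenzyl groups on the amide-type nitrogen would address this. From the compounds shown here alone, how an amine or a carboxylic acid on that aromatic ring would read in this assay also remains open.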